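Series notes: expectation for compound 4 from compounds 1 to 3

A few compounds are considered here, and "the series" means these few. Any claim that something is new, unique, unknown or untested is made for them only; others in the source may bear on it.

Measured so far:
Compound 1, `CSc1c(C#N)c(N)c(C#N)c(-c2ccccc2)c1-c1ccccc1`, gives 7.4% in an assay on isolated protein for inhibition of glucose-6-phosphatase catalytic subunit 1 (Homo sapiens), tested at 100 uM; on this read-out higher numbers stand for more inhibition at the one concentration tested (going by the name of the read-out) and lower numbers for less inhibition.
Compound 2, `COc1ccc(-c2c(C#N)c(N)c(C#N)c(SC)c2-c2ccccc2)cc1`, gives 6.8%.
Compound 3, `COc1ccc(-c2c(C#N)c(N)c(C#N)c(SC)c2-c2ccc(F)cc2)cc1`, gives 5.5%.

Compound 3 is not separated from compound 2 or compound 1 beyond the scatter; the three numbers lie together at low inhibition. The steps shown are a number 0.6 percentage points lower from compound 1 to compound 2 (within the scatter) and a number 1.3 percentage points lower from compound 2 to compound 3 (within the scatter), both within the scatter.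

Compound 4 is `CSc1c(C#N)c(N)c(C#N)c(C)c1-c1ccc(F)cc1`. The change is methyl in place of 4-methoxyphenyl on an aromatic carbon. No measured step covers a change of this kind; the two shown steps concern other positions and are both within the scatter. The expected step of a number 0.5 percentage points higher from compound 3 to compound 4 (within the scatter) is therefore none beyond the scatter. Compound 4 is estimated at 6%, range -2% to 14%.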

Compound 4, a percentage reported as inhibition, at one concentration (the size of the read-out at that concentration, not a potency): 41.8%
Estimate against measurement, compound 4: 35.8 percentage points below, outside the stated range (above it).
By their numbers in this assay, from the lowest: compounds 3, 2 and 1 (each within the scatter of the next); then compound 4.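

On this assay, this position, ortho to the 4-fluorophenyl group and to a cyano group, proves sensitive to its substituent: methyl in place of 4-methoxyphenyl reads a number 36.3 percentage points higher from compound 3 to compound 4 (beyond the scatter) and is the only step shown beyond the scatter. The earlier steps shown here, at other positions, showed no such response. Nothing at hand accounts for this step.

The compounds shown leave open whether an ethyl group, a longer chain or an amine at this position would read like methyl or like 4-methoxyphenyl. From the compounds shown here alone, whether the step holds without the fluoro on the 4-fluorophenyl group also stays open.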